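The compounds below may be only part of what the source reports. "The series", "measured", "known", "first", "only" and "open" are said of these compounds alone.

Working notes on the series. Three compounds have been run so far: compound 1 `CSCC[C@H](NC(=O)c1ccc(NCc2cncn2Cc2ccccc2C#N)cc1-c1ccccc1)C(=O)O`, compound 2 `COC(=O)[C@H](CCSC)NC(=O)c1ccc(NCc2cncn2Cc2ccc(C)cc2)cc1-c1ccccc1` and compound 3 `N#Cc1ccc(Cn2cncc2CNc2ccc(C(=O)Nc3cccc([N+](=O)[O-])c3)c(-c3ccccc3)c2)cc1`. In a functional assay on NIH3T3 cells (Mus musculus) (a higher number here means that more compound is needed for the effect, a lower number that less compound is needed), compound 1 reaches only the limit of the measurement, > 10 uM, and no number. In this assay compound 2 likewise gives only the limit > 10 uM. Compound 3 also returns only the limit > 10 uM in this assay, so nothing distinguishes it from the other two on the numbers at hand; the whole picture is summed up by the limit of > 10 uM in this assay, at which 3 of the 3 values shown sit. For the measured compounds named here, no step between two measured compounds exists in this set, so no measured size of change is available for comparison.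

The next compound, compound 4 `N#Cc1ccc(Cn2cncc2CNc2ccc(C(=O)Nc3cccc(C#N)c3)c(-c3ccccc3)c2)cc1`, differs from compound 3 in one place: cyano in place of nitro on an aromatic carbon. Going by the values given here, because compound 3 sits at the limit > 10 uM, there is no number from which a step could be measured, and the change itself has no precedent here. The expectation for compound 4 in this assay is therefore no movement beyond the scatter, an estimated step that the limit leaves unreadable from compound 3 to compound 4. Compound 4 is accordingly expected at about 15 uM, with a range from 4 uM to 60 uM, and most likely again only a limit.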

Compound 4, concentration for half-maximal effect: > 10 uM
Compound 4: no number, only a limit; the forecaster's own chance of this, stated with the estimate: 75%; the middle value lies beyond the limit too.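

In this assay compound 4 gives > 10 uM, a limit and not a number. Compound 3 sits at a limit too, so no step between compound 3 and compound 4 can be read: the limit of > 10 uM in this assay, at which 4 of the 4 values shown sit.

The compounds shown leave open whether cyano in place of nitro on an aromatic carbon changes the response in this assay at all.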